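The compounds below may be only part of what the source reports. "The series", "measured", "known", "first", "only" and "open" are said of these compounds alone.

Two stilbene-type compounds have been measured here: compound 1 `Nc1ccc(/C=C/c2ccccc2O)cc1` and compound 2 `COc1ccccc1/C=C/c1ccc(O)cc1`. In a functional assay on MCF7 cells (Homo sapiens) for inhibition, read by MTT assay, with a stated time of 2 days (on this read-out higher numbers stand for weaker inhibition and lower numbers for stronger inhibition), compound 1 gives 23 ug/mL, and in this assay compound 2 gives 19 ug/mL. Of the two numbers, compound 2 holds the lowest, though the gap to compound 1 is within the scatter, so the two cannot be told apart on this read-out.

Compound 3 `COc1ccccc1/C=C/c1ccc(N)cc1` has not yet been measured. It differs from compound 2 in one place: amino in place of hydroxy on an aromatic carbon. For the measured compounds named here, no measured pair isolates this exchange, so its size is unknown from the data. The two measured compounds both lie close together, which gives no ground to expect a step beyond the scatter in either direction.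

Compound 3 is therefore expected to give about 20 ug/mL, within a range of 10 ug/mL to 40 ug/mL, an expected step of a 1.1-fold higher number from compound 2 to compound 3 (0.02 log units; within the scatter).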

Compound 3, half-maximal inhibitory concentration: 3.2 ug/mL
The estimate for compound 3 lay 6.3-fold (0.80 log units) above the measured number, outside the stated range (below it).
By their numbers in this assay, from the lowest: compound 3; then compounds 2 and 1 (each within the scatter of the next).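

With the methoxy side held fixed, amino in place of hydroxy on an aromatic carbon, para to a large group, gives a 5.9-fold lower number from compound 2 to compound 3 (0.77 log units; beyond the scatter) in this assay, so this position responds to the exchange. With the amino held fixed, methyl in place of hydrogen on an oxygen on an aromatic ring gives a 7.2-fold lower number from compound 1 to compound 3 (0.86 log units; beyond the scatter) as well, so among these compounds only the one carrying both the amino and the methoxy stands apart, while compounds 1 and 2, which each keep a hydroxy, cannot be told apart. Nothing available here accounts for this step.

As far as these compounds go, whether the amino itself is required stays open, as a dimethylamino or an acetamide at this position could show. From the compounds shown here alone, it is also open whether an ethoxy could take the place of the methoxy.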